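Adding one methyl to compound 2

The source may hold more compounds than are shown below. What is called first, only, known or untested is meant among the compounds shown, and "the series" means these compounds.

Of the compounds shown here, two have been tested so far in a functional assay on the whole organism for antagonist activity, with Mus musculus as the target; a lower number here means that less compound is needed, a higher number that more compound is needed for the effect. Among the measured compounds shown here, compound 1 (`CCOC(=O)N(C)CC#CCn1cncc1C`) gives 66 mg/kg and compound 2 (`CCOC(=O)N(C)C(C)C#CCn1ccnc1`) gives 54 mg/kg, so compound 2 stands within the usual scatter of compound 1, its only measured neighbour. Compound 3 (`CCOC(=O)N(C)C(C)C#CCn1cncc1C`) is compound 2 with a methyl in place of hydrogen on an aromatic carbon, which turns 1H-imidazol-1-yl into 5-methyl-1H-imidazol-1-yl: methyl in place of hydrogen on an aromatic carbon. The same 5-methyl-1H-imidazol-1-yl group is already present in compound 1 at 66 mg/kg, a value close to that of compound 2. For the measured compounds named here, no measured pair isolates this change, so the expected size of the step is none beyond the scatter, a 1.1-fold lower number from compound 2 to compound 3 (0.03 log units; within the scatter). For compound 3 the estimated dose in this assay is 50 mg/kg, with an expected range of 22 mg/kg to 110 mg/kg.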

Compound 3, dose for half-maximal effect: 9.7 mg/kg
Compound 3: middle estimate off by 5.2-fold (0.71 log units), on the high side; measured number below the stated range.
By their numbers in this assay, from the lowest: compound 3; then compounds 2 and 1 (each within the scatter of the next).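

In this assay, replacing hydrogen with methyl on an aromatic carbon, which turns 1H-imidazol-1-yl into 5-methyl-1H-imidazol-1-yl, gives a 5.6-fold lower number from compound 2 to compound 3 (0.75 log units; beyond the scatter), so this position matters when the chain methyl is already in place. The chain methyl also counts when the ring methyl is present, with a 6.8-fold lower number from compound 1 to compound 3 (0.83 log units; beyond the scatter), and only the compound carrying both methyls stands apart from the other two. No measurement here explains why so small a change has this effect.

The compounds shown leave open how a compound with neither methyl would compare, and so whether each methyl would have the same effect without the other. They also leave open whether ethyl or a chlorine atom at the same aromatic carbon would lower the number further, keep it, or raise it.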